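The source may report more compounds than this note shows. Statements on the series, on what has been measured and on what is new or still open speak of the compounds shown alone.

Compound 1 `COc1ccc(N/C=C\C(=O)c2cn(-c3ccccc3)nc2-c2ccccc2)cc1` and compound 2 `COc1cc(N/C=C\C(=O)c2cn(-c3ccccc3)nc2-c2ccccc2)cc(OC)c1OC` were both examined in a functional assay on HT-29 cells (Homo sapiens) for antiproliferative activity, read by MTT assay, with a stated time of 48 h; a lower number here means a stronger inhibitor, a higher number a weaker inhibitor. Compound 1 gives 1560 nM there, while compound 2 gives 9800 nM, the higher of the two numbers and therefore the weaker of the pair. Compound 3 `COc1ccc(-c2nn(-c3ccccc3)cc2C(=O)/C=C\Nc2cc(OC)c(OC)c(OC)c2)cc1` differs from compound 2 only by methoxy in place of hydrogen on an aromatic carbon. Among the compounds with values here, no measured pair isolates this change, so nothing in the data sets its size, and the expected step is small, either downward or none beyond the scatter. Compound 3 is estimated at 7000 nM, with a range from 2500 nM to 20000 nM. The expected step is a 1.4-fold lower number from compound 2 to compound 3 (0.15 log units; within the scatter).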

Compound 3, half-maximal inhibitory concentration: 14600 nM
Compound 3: middle estimate off by 2.1-fold (0.32 log units), on the low side, within the range that was stated.
By their numbers in this assay, from the lowest: compound 1; then compounds 2 and 3 (each within the scatter of the next).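

In this assay the change from phenyl to 4-methoxyphenyl gives a 1.5-fold higher number from compound 2 to compound 3 (0.17 log units; within the scatter) and this lies within the scatter, so this pair shows no readable effect of methoxy in place of hydrogen at this place, para to a large group. The earlier compounds shown here carried no substituent here and could not show this. No available evidence bears on this result. From the compounds shown here alone, whether an amine, a carboxylic acid or a longer chain such as butoxy at this place would shift the number beyond the scatter remains open.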